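The source may hold more compounds than are shown below. What is called first, only, known or untested is meant among the compounds shown, and "the series" means these compounds.

Measured compounds:
compound 1, `CCn1cc(-c2ccnc(Nc3ccc(OC)cc3OC)n2)c2ccccc21`: 3590 nM
compound 2, `CNc1nc(C)c(-c2ccnc(Nc3ccc(OC)cc3OC)n2)s1`: 300 nM

Both compounds were tested in a functional assay on MV4-11 cells (Homo sapiens) for inhibition, read by resazurin assay, with a stated time of 72 h; on this read-out higher numbers stand for weaker inhibition of growth and lower numbers for stronger inhibition of growth. Compound 1 gives 3590 nM, while compound 2 gives 300 nM. Of the two numbers, compound 2 has the lower one; compound 1 is the nearest neighbour and its number is higher by a gap that lies beyond the usual scatter, so compound 2 is the stronger growth inhibitor of the pair. Among the compounds with values here, the two compounds share the same anilino-pyrimidine part but carry different ring systems on it, so they do not form a single-point step and no step between them can be stated.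

Compound 3, `COCCSc1nc(C)c(-c2ccnc(Nc3ccc(OC)cc3OC)n2)s1`, is not yet measured. It differs from compound 2 in one place: (2-methoxyethyl)sulfanyl in place of methylamino on an aromatic carbon. Within the data shown here, no measured pair shows a change of this kind, so the expectation rests on compound 2 alone. The step is estimated to be a 3.3-fold higher number from compound 2 to compound 3 (0.52 log units; beyond the scatter), toward weaker inhibition, with wide uncertainty. Compound 3 is therefore expected to give about 1000 nM in this assay, within a range from 300 nM to 4000 nM.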

Compound 3, concentration for 50% growth inhibition: 810 nM
The estimate for compound 3 lay 1.2-fold (0.09 log units) above the measured number; low and high end bracket the measured number.
By their numbers in this assay, from the lowest: compound 2; then compound 3; then compound 1.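

In this assay, putting (2-methoxyethyl)sulfanyl in place of methylamino on the aromatic carbon of the five-membered ring gives a 2.7-fold higher number from compound 2 to compound 3 (0.43 log units; beyond the scatter) and so moves toward weaker inhibition of growth. This shows that the position responds to what it carries, though the step is modest: with the larger group that has no hydrogen-bond donor, compound 3 still gives 810 nM and growth inhibition is not lost. The swap changes the size of the group, the atom attached to the ring and the donor count all at once, and no measurement here ties the step to any one of these or gives a reason for it.

The compounds shown leave open whether the chain or the sulfur link accounts for the step, a question that a 2-methoxyethylamino group, which keeps the chain on a nitrogen, or a short methylsulfanyl group, which keeps the sulfur without the chain, could help to separate. They also leave open how a plain amino group or a carboxylic acid at this position would read out.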